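This account rests on a few compounds, and the source may have more. Where it says the series, first, only, none or still open, it means among the compounds named here.

Of the compounds shown here, three built on one shared core have been tested in a functional assay on cells for agonist activity at Free fatty acid receptor 1 (Homo sapiens), read by FLIPR and calcium flux, with a stated time of 100 s; on this read-out lower numbers stand for an effect already at smaller amounts and higher numbers for an effect only at larger amounts of compound. Compound 1 `Cc1ccccc1Oc1ccc(N2CCC[C@H]2CC(=O)O)cc1` gives 74 nM, compound 2 `O=C(O)C[C@@H]1CCCN1c1ccc(Oc2ccccc2F)cc1` gives 150 nM, and compound 3 `O=C(O)C[C@@H]1CCCN1c1ccc(Oc2cccc(Cl)c2)cc1` gives 680 nM. Compound 3 therefore has the highest number of the three: compound 2 lies a 4.5-fold higher number from compound 2 to compound 3 (0.66 log units; beyond the scatter) away, and compound 1 a 9.2-fold higher number from compound 1 to compound 3 (0.96 log units; beyond the scatter) away. The change from compound 3 to compound 4 `Cc1ccc(Oc2ccc(N3CCC[C@H]3CC(=O)O)cc2)cc1` is 4-methylphenyl in place of 3-chlorophenyl on an oxygen on an aromatic ring. For the measured compounds named here, no measured step makes this exact swap. The two steps that end at compound 3, a 9.2-fold higher number from compound 1 to compound 3 (0.96 log units; beyond the scatter) and a 4.5-fold higher number from compound 2 to compound 3 (0.66 log units; beyond the scatter), both rise when the 3-chlorophenyl enters, whereas a 2.0-fold higher number from compound 1 to compound 2 (0.31 log units; beyond the scatter) is smaller. Going by the values given here, the only methyl-bearing compound, compound 1, gives 74 nM, but as 2-methylphenyl rather than 4-methylphenyl, so its number cannot simply be carried over. A modest fall from compound 3 to compound 4 is expected, a 2.3-fold lower number from compound 3 to compound 4 (0.36 log units; beyond the scatter), with wide uncertainty. Compound 4 is estimated at 300 nM, within a range from 100 nM to 1000 nM.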

Compound 4, half-maximal effective concentration: 490 nM
For compound 4 the middle estimate is 1.6-fold (0.21 log units) below the measured one; low and high end bracket the measured number.
By their numbers in this assay, from the lowest: compound 1; then compound 2; then compounds 4 and 3 (each within the scatter of the next).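

In this assay, 4-methylphenyl in place of 3-chlorophenyl on the oxygen gives a 1.4-fold lower number from compound 3 to compound 4 (0.14 log units; within the scatter), so this swap of a chlorine-bearing ring for a methyl-bearing one cannot be told apart from repeat scatter. Moving the methyl group alone does register, with 4-methylphenyl in place of 2-methylphenyl giving a 6.6-fold higher number from compound 1 to compound 4 (0.82 log units; beyond the scatter), and 4-methylphenyl in place of 2-fluorophenyl gives a 3.3-fold higher number from compound 2 to compound 4 (0.51 log units; beyond the scatter), so among these four compounds the 2-methylphenyl and 2-fluorophenyl rings both have lower numbers than the 3-chlorophenyl and 4-methylphenyl rings, with no compound against that pattern. Nothing available explains why these steps differ in size. Still open, on these data alone, is how 3-methylphenyl and 4-chlorophenyl would compare, which would help separate the place on the ring from the identity of the group. Also open, as far as these compounds go, is whether a methoxy group or a nitrile on this ring would fit the same pattern.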